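The compounds below may be only part of what the source reports. "The series", "measured", "known", "first", "only" and "open" are said of these compounds alone.

Three compounds share one core and differ only in the length of a straight saturated chain attached to an aromatic nitrogen. In a functional assay on MGC-803 cells (Homo sapiens) for antiproliferative activity, read by MTT assay, with a stated time of 48 h (on this read-out higher numbers stand for weaker inhibition and lower numbers for stronger inhibition), compound 1 `CCCCCCCCn1cc(COC[C@@H]2OC[C@H](N)[C@H]2O)nn1` reaches only the limit of the assay, > 128000 nM, so no number is available for it. Within the data shown here, compound 2 `CCCCCCCCCCn1cc(COC[C@@H]2OC[C@H](N)[C@H]2O)nn1` gives 57400 nM in this assay and is the only compound with a measured number. The other value shown, that of compound 1, is a limit: the limit of > 128000 nM in this assay, at which 1 of the 2 values shown sits. Among the measured compounds shown here, the one measured step, an at least 2.2-fold lower number from compound 1 to compound 2 (0.34 log units; beyond the scatter), goes toward stronger inhibition when the chain is lengthened. Compound 3 `CCCCCCCCCCCCCCCCn1cc(COC[C@@H]2OC[C@H](N)[C@H]2O)nn1` carries the same kind of change taken further: hexyl in place of hydrogen on a saturated chain carbon, ten or more bonds along the chain from an aromatic nitrogen. For the measured compounds named here, the only comparable step an at least 2.2-fold lower number from compound 1 to compound 2 (0.34 log units; beyond the scatter) came with chain growth, so a further lowering of the number is expected, although one step is a thin basis and the new change is considerably larger than the one already measured. Compound 3 is therefore estimated to give 15000 nM in this assay, with a likely range from 3000 nM to 60000 nM. This estimate corresponds to an expected step of a 3.8-fold lower number from compound 2 to compound 3 (0.58 log units; beyond the scatter).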

Compound 3, half-maximal inhibitory concentration: 5340 nM
Beside the measured number, compound 3's estimate is 2.8-fold (0.45 log units) above it; measured number inside the range.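

In this assay, the direction seen with the first lengthening of the chain holds for a much larger change: hexyl in place of hydrogen on a saturated chain carbon, ten or more bonds along the chain from an aromatic nitrogen, gives an 11-fold lower number from compound 2 to compound 3 (1.03 log units; beyond the scatter). This step is large, whereas the earlier one was at least modest, so this far out on the chain added carbon continues to go with stronger inhibition, and none of the three compounds goes against that pattern. Over the whole series the result is an at least 23-fold lower number from compound 1 to compound 3 (1.37 log units; beyond the scatter), but that figure is only a lower bound on the real difference because the value of compound 1 is a limit and not a number: the limit of > 128000 nM in this assay, at which 1 of the 3 values shown sits.

Among these compounds, with only three chain lengths, it remains open whether a longer chain than that of compound 3 would lower the number further or whether the fall would level off or reverse. On these data alone, it is also open whether a chain ending in an amine or a carboxylic acid would keep this gain, and the numbers alone give no reason why length matters.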